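A few compounds are considered here, and "the series" means these few. Any claim that something is new, unique, unknown or untested is made for them only; others in the source may bear on it.

Measured so far:
- compound 1, `COc1cc(C)cc(-c2nn(CC#N)cc2-c2ccc(-c3cccc(C(C)=O)c3)nc2)c1`: 99%
- compound 2, `Cc1cc(O)cc(-c2nn(CC#N)cc2-c2ccnc(-c3ccc(Oc4ccccc4)cc3)c2)c1`: 88%
- compound 3, `COc1cc(C)cc(-c2nn(CC#N)cc2-c2ccnc(-c3ccc(N(C)C)cc3)c2)c1`: 103%

All three numbers come from a functional assay on SF-268 cells (Homo sapiens) for cytotoxicity, read by sulforhodamine B assay, with a stated time of 48 h, tested at 0.001 uM; on this read-out higher numbers stand for a weaker effect at the one concentration tested and lower numbers for a stronger effect. Among the compounds with values here, on this read-out compound 3 gives 103%, a number that sits within the scatter of the one for compound 1 and is separated from the one for compound 2 by a gap beyond the scatter. At the single concentration used, all three numbers point to little effect on the cells.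

Compound 4, `Cc1cc(O)cc(-c2nn(CC#N)cc2-c2ccnc(-c3ccc(N(C)C)cc3)c2)c1`, has not yet been measured in this assay. It differs from compound 3 in one place: hydrogen in place of methyl on an oxygen on an aromatic ring. Within the data shown here, no pair of measured compounds differs in only this place, so the size of such a step is not known from the series itself. Compound 2 carries the hydroxy group and gives 88%, but compound 2 also differs from compound 3 elsewhere in the structure, so its number cannot be read as the effect of this one change.

The expected step from compound 3 to compound 4 is a number 7 percentage points lower from compound 3 to compound 4 (within the scatter), toward a lower number but not clearly beyond the scatter. Compound 4 is expected to give 96% in this assay, with a range from 84% to 106%.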

Compound 4, a percentage reported as activity, at one concentration (the size of the read-out at that concentration, not a potency): 97%
Compound 4: the middle estimate sits 1 percentage points below what was measured; measured number inside the range.
By their numbers in this assay, from the lowest: compounds 2, 4, 1 and 3 (each within the scatter of the next, the first and the last beyond it).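

In this assay, within the data shown here, the series now holds a first matched pair for methoxy to hydroxy, and the step is a number 6 percentage points lower from compound 3 to compound 4 (within the scatter) so hydrogen in place of methyl on an oxygen on an aromatic ring does not separate these two compounds at the one concentration tested. Compound 4 also gives a second matched pair, at a different place in the structure: dimethylamino in place of phenoxy on an aromatic carbon gives a number 9 percentage points higher from compound 2 to compound 4 (within the scatter) and so does not separate that pair either. No measurement in hand bears on the reason for either step.

The compounds shown leave open whether an ethoxy group or an amino group at this place on the aromatic ring would read differently, and whether methoxy to hydroxy gives a similar step when phenoxy stands in place of dimethylamino. Each number also comes from a single low concentration, so the pairs say nothing about potency or about how these compounds would compare at concentrations where the cells respond more clearly.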